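A few compounds are considered here, and "the series" means these few. Any claim that something is new, unique, unknown or untested is made for them only; others in the source may bear on it.

Measured compounds:
compound 1 `CCOc1ccccc1-c1ccc(-c2nc3cnccc3c(N[C@H](CC(C)C)C(N)=O)c2C#N)cc1`, 3.4
compound 2 `CCOc1ccccc1-c1ccc(-c2nc3cnccc3c(NC(C)C(=O)O)c2C#N)cc1`, 2.1
compound 3 `CCOc1ccccc1-c1ccc(-c2nc3cnccc3c(NC(CC)CNS(=O)(=O)C3CC3)c2C#N)cc1`, 3.6

In a physicochemical assay for lipophilicity, read by HPLC, at pH 7.5 (on this read-out higher numbers stand for higher lipophilicity and lower numbers for lower lipophilicity), compound 3 stands highest of the three numbers. The step of a number 0.20 log units higher from compound 1 to compound 3 (within the scatter) is within the scatter, so compounds 1 and 3 are not told apart; the step of a number 1.50 log units higher from compound 2 to compound 3 (beyond the scatter) is large, as is a number 1.30 log units lower from compound 1 to compound 2 (beyond the scatter).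

Compound 4 `CCOc1ccccc1-c1ccc(-c2nc3cnccc3c(N[C@H](CC)C(=O)NS(C)(=O)=O)c2C#N)cc1` differs from compound 3 in one place: a group of 10 heavy atoms (5 carbon, 1 nitrogen, 3 oxygen, 1 sulfur; no ring) in place of a group of 11 heavy atoms (7 carbon, 1 nitrogen, 2 oxygen, 1 sulfur; one three-membered non-aromatic ring of carbon only), on a nitrogen on an aromatic ring. Among the measured compounds shown here, no measured step carries this entering group. The two large steps show that exchange at this nitrogen can move this assay widely, with the carboxyethyl of compound 2 at the low end. The entering group, with no ring and fewer carbons than the leaving group, is expected to give a step downward, a number 1.30 log units lower from compound 3 to compound 4 (beyond the scatter). Compound 4 is estimated at 2.3, range 1.6 to 3.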

Compound 4, distribution coefficient: 2.2
Estimate against measurement, compound 4: 0.10 log units above, within the range that was stated.
By their numbers in this assay, from the lowest: compounds 2 and 4 (each within the scatter of the next); then compounds 1 and 3 (each within the scatter of the next).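

In this assay the step of a number 1.40 log units lower from compound 3 to compound 4 (beyond the scatter) shows that two groups both carrying sulfur can lie far apart on this nitrogen. With a number 0.10 log units higher from compound 2 to compound 4 (within the scatter) and a number 1.20 log units lower from compound 1 to compound 4 (beyond the scatter) in view, the carboxyethyl of compound 2 no longer stands alone at the low end of these numbers. Nothing at hand gives a reason for these steps. Open, going by these compounds, is whether a simple amine or a methyl ester on this nitrogen would fall with compounds 2 and 4 or with compounds 1 and 3. Also open, on these data alone, is what a longer chain in place of the ethyl of compound 4 would do in this assay on this read-out.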